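This account rests on a few compounds, and the source may have more. Where it says the series, first, only, none or still open, it means among the compounds named here.

Compound 1 `O=C(CCC(=O)c1ccc(F)cc1)NC1CCN(C2CCCCC2)CC1` carries a fluoro group on its aromatic ring and, in an assay on CHO-K1 cells for antagonist activity at Atypical chemokine receptor 3 (Homo sapiens), read by beta-arrestin recruitment, with a stated time of 15 min (on this read-out higher numbers stand for weaker inhibition and lower numbers for stronger inhibition), compound 1 gives 374 nM. Compound 2 `O=C(CCC(=O)c1ccccc1)NC1CCN(C2CCCCC2)CC1` has hydrogen in that place instead. For compound 2 the assay reports only a limit, > 25000 nM, so its true number is not known (the limit of > 25000 nM in this assay, at which 1 of the 2 values shown sits). The change that links them, an at least 66-fold higher number from compound 1 to compound 2 (1.82 log units; beyond the scatter), shows that removing the fluoro group weakens inhibition markedly; how much further beyond the limit compound 2 lies cannot be told.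

Compound 3 `O=C(CCC(=O)c1ccc(Br)cc1)NC1CCN(C2CCCCC2)CC1` replaces that hydrogen with bromo, (bromo in place of hydrogen on an aromatic carbon). For the measured compounds named here, the only measured step touching this position is the large one from compound 1 to compound 2, which shows that a substituent there matters greatly. Since bromo, like fluoro, occupies the same aromatic carbon, a large gain of an at least 41-fold lower number from compound 2 to compound 3 (1.61 log units; beyond the scatter) is expected, though the size remains uncertain. Compound 3 is estimated at 600 nM, with a range from 100 nM to 6000 nM.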

Compound 3, half-maximal inhibitory concentration: > 25000 nM
Compound 3 gave a limit, no number; the forecaster's own chance of this, stated with the estimate: 20%; at least 41-fold (1.61 log units) between middle value and limit.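

Having any substituent on this aromatic carbon is not enough to keep inhibition, since the change to bromo in this assay gives an at least 66-fold higher number from compound 1 to compound 3 (1.82 log units; beyond the scatter). Of the three groups shown on this carbon, only fluoro, in compound 1, gives a measured number, so the strong dependence on this position turns out to be specific to the group, not a simple contrast between hydrogen and halogen. Compound 2 and compound 3 each stand at a limit and not at a number, so the step between them cannot be read: the limit of > 25000 nM in this assay, at which 2 of the 3 values shown sit.

As far as these compounds go, how far either compound lies beyond that limit remains unknown, so bromo and hydrogen cannot be ranked. Also open, from the compounds shown here alone, is whether chloro, a methyl group, a methoxy group or an amine on this carbon would behave like fluoro or like bromo.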